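Dicaffeoylquinic acid methyl ester series: stereochemical variant

The source may hold more compounds than are shown below. What is called first, only, known or untested is meant among the compounds shown, and "the series" means these compounds.

Two compounds of the series carry numbers. Compound 1 `O=C(/C=C\c1ccc(O)cc1)O[C@@H]1C[C@](OC(=O)/C=C/c2ccc(O)cc2)(C(=O)O)C[C@@H](O)[C@H]1O` in a functional assay on BV-2 cells (Mus musculus) for inhibition, read by Griess assay, with a stated time of 10 min (a higher number here means a weaker inhibitor, a lower number a stronger inhibitor), gives 59800 nM. Compound 2 `COC(=O)[C@@]1(O)C[C@@H](O)[C@H](OC(=O)/C=C/c2ccc(O)c(O)c2)[C@H](OC(=O)/C=C/c2ccc(O)c(O)c2)C1` in this assay gives 20200 nM, the lowest of the two numbers; the nearest is compound 1, whose number is higher by a margin beyond the scatter. Going by the values given here, no pair of measured compounds differs in a single place, so no single step has been measured.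

Compound 3 `COC(=O)[C@]1(O)C[C@@H](O)[C@@H](OC(=O)/C=C/c2ccc(O)c(O)c2)[C@H](OC(=O)/C=C/c2ccc(O)c(O)c2)C1` is unmeasured. Its relation to compound 2 is purely one of configuration: the two compounds have the same atoms and bonds and differ only in configuration as drawn: 2 of 6 stereo elements differ; a stereocentre at a saturated ring carbon is drawn R in compound 2 and S in compound 3; a stereocentre at a saturated ring carbon is drawn S in compound 2 and R in compound 3. Nothing in the data shows how a change of configuration alone moves the number in this assay, since compound 1 and compound 2 differ in several places at once. The expectation for the step from compound 2 to compound 3 is therefore a small change, within the scatter, with no preferred direction: a 1.2-fold higher number from compound 2 to compound 3 (0.09 log units; within the scatter). On that basis compound 3 is estimated in this assay at 25000 nM, expected to fall between 8000 nM and 80000 nM.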

Compound 3, half-maximal inhibitory concentration: 24600 nM
Beside the measured number, compound 3's estimate is 1.0-fold (0.01 log units) above it; the measured number falls inside the stated range.
By their numbers in this assay, from the lowest: compounds 2 and 3 (each within the scatter of the next); then compound 1.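

Going by these compounds alone, the pair gives the first single step, and that step isolates configuration: the fact that compounds 2 and 3 differ only in the configuration as drawn. Exchanging the drawn configuration at two saturated ring carbons, one going from R to S and the other from S to R, gives in this assay a 1.2-fold higher number from compound 2 to compound 3 (0.09 log units; within the scatter), so this change of configuration alone does not separate the two methyl esters. This reading holds only for this one pair and this particular double change, with the two ester side chains and the methyl ester unchanged.

The two stereocentres change together, which leaves the contribution of each one on its own unresolved, and compound 1 differs from compound 2 in several places at once, so the gap between their numbers cannot be assigned to any single group. From the compounds shown here alone, it also remains open whether replacing the methyl ester with an amide or a longer-chain ester would move the number in this assay, and whether either replacement would make the number respond to configuration at these carbons.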